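The source may report more compounds than this note shows. Statements on the series, on what has been measured and on what is new or still open speak of the compounds shown alone.

In a functional assay on SGC-7901 cells (Homo sapiens) for antiproliferative activity, read by MTT assay, with a stated time of 24 h (on this read-out lower numbers stand for stronger inhibition and higher numbers for weaker inhibition), compound 1 (`O=C(NNc1cccc(Cl)c1)c1cccc(NS(=O)(=O)c2cnc(O)nc2O)c1`) gives 11800 nM, within the scatter of the two other measured compounds: compound 2 (`CCCCOc1ccc(C(=O)NNC(=O)c2ccc(NS(=O)(=O)c3cnc(O)nc3O)cc2)cc1`) gives 14700 nM and compound 3 (`O=C(NNC(=O)c1cccc(Cl)c1)c1ccc(NS(=O)(=O)c2cnc(O)nc2O)cc1`) gives 8610 nM. Compound 4 (`O=C(NNC(=O)c1ccccc1Cl)c1cccc(NS(=O)(=O)c2cnc(O)nc2O)c1`) differs from compound 1 by (2-chlorophenyl)carbonyl in place of 3-chlorophenyl on an amine nitrogen. For the measured compounds named here, no measured step tests this exchange directly. The nearest is a 1.7-fold lower number from compound 2 to compound 3 (0.23 log units; within the scatter), which stays within the scatter. Compound 3 also carries a carbonyl on that amine nitrogen, and its 8610 nM lies within the scatter of compound 1. No change beyond the scatter is therefore expected in this assay. The expected step is a 1.2-fold lower number from compound 1 to compound 4 (0.07 log units; within the scatter). For compound 4, the estimated value is 10000 nM, with an expected range of 5000 nM to 20000 nM.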

Compound 4, half-maximal inhibitory concentration: 6070 nM
Beside the measured number, compound 4's estimate is 1.6-fold (0.22 log units) above it; measured number inside the range.
By their numbers in this assay, from the lowest: compounds 4, 3, 1 and 2 (each within the scatter of the next, the first and the last beyond it).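

In this assay the exchange of 3-chlorophenyl for (2-chlorophenyl)carbonyl on this amine nitrogen gives a 1.9-fold lower number from compound 1 to compound 4 (0.29 log units; within the scatter) and so leaves the number within the scatter. This step tests the exchange on the amine nitrogen directly, whereas the earlier step concerned a group on a carbonyl carbon. Nothing available here explains the result.

As far as these compounds go, the step adds the carbonyl and moves from 3-chlorophenyl to 2-chlorophenyl together, so the part each plays remains open. Also open, from the compounds shown here alone, is how an acetyl group or a carboxylic acid would behave on this nitrogen.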